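Shortening the chain of compound 1

A few compounds are considered here, and "the series" means these few. Any claim that something is new, unique, unknown or untested is made for them only; others in the source may bear on it.

Measured so far:
- Compound 1 `CCCCCCCCOP(=O)(O)OCCSC(=S)N1CCCC1`: 53000 nM
- Compound 2 `CCCCCCCCOP(=O)(O)OCCSC(=S)N1CCCCCC1`: 78000 nM

Within the data shown here, in a functional assay on MCF7 cells (Homo sapiens) for inhibition, read by MTT assay, with stated times of 18 h and 4 h (on this read-out higher numbers stand for weaker inhibition and lower numbers for stronger inhibition), compound 1 gives 53000 nM, and compound 2, the only other measured compound, lies within the scatter of it. Compound 3 `CCCOP(=O)(O)OCCSC(=S)N1CCCC1` keeps the core of compound 1 and alters only the chain: hydrogen in place of pentyl on a saturated chain carbon, three bonds along the chain from an oxygen on an unsaturated carbon. Among the measured compounds shown here, the one measured step, a 1.5-fold higher number from compound 1 to compound 2 (0.17 log units; within the scatter), exchanges pyrrolidin-1-yl for azepan-1-yl on a thiocarbonyl carbon and leaves the chain untouched, so it gives no direct size for this change. Losing a pentyl is nevertheless a larger edit than the exchange in that step, so a move beyond the scatter towards weaker inhibition is expected, with wide uncertainty. The expected step is a 3.4-fold higher number from compound 1 to compound 3 (0.53 log units; beyond the scatter). Compound 3 is estimated at 180000 nM, with an expected range of 70000 nM to 450000 nM.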

Compound 3, half-maximal inhibitory concentration: 73000 nM
For compound 3 the middle estimate is 2.5-fold (0.39 log units) above the measured one; the measured number falls inside the stated range.
By their numbers in this assay, from the lowest: compounds 1, 3 and 2 (each within the scatter of the next).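

In this assay, among these compounds, hydrogen in place of pentyl on this saturated chain carbon gives a 1.4-fold higher number from compound 1 to compound 3 (0.14 log units; within the scatter) and is the first measured step at the chain. Pentyl and hydrogen cannot be told apart here in this read-out, although the edit removes 5 heavy atoms. With a 1.5-fold higher number from compound 1 to compound 2 (0.17 log units; within the scatter) on the thiocarbonyl carbon also read, neither place has yet separated any of the compounds, and no supporting data bear on this result.

Going by these compounds, whether a longer chain, or an amine or a carboxylic acid at the end of the chain, would move the number beyond the scatter remains open. Also open, on these data alone, is whether the same shortening would give a similar step with azepan-1-yl on the thiocarbonyl carbon.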